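This account rests on a few compounds, and the source may have more. Where it says the series, first, only, none or still open, it means among the compounds named here.

Compound 1, `COC1Cc2sccc2C2(CCN(CCCCc3ccccc3)CC2)O1`: in an assay on membranes from brain for displacement of a labelled ligand from Sigma non-opioid intracellular receptor 1 (Cavia porcellus) (on this read-out lower numbers stand for stronger inhibition and higher numbers for weaker inhibition), compound 1 gives 7.7 nM.
Compound 2, `COc1ccc(CN2CCC3(CC2)OC(OC)Cc2sccc23)cc1`: in this assay compound 2 gives 2.2 nM.

Of these two numbers, compound 2 holds the lowest; its nearest neighbour is compound 1, whose number is higher by a margin that lies beyond the usual scatter. Compound 3, `CCCCN1CCC2(CC1)OC(OC)Cc1sccc12`, is the next to be measured. It differs from compound 2 in one place: propyl in place of 4-methoxyphenyl on a saturated chain carbon bound to an amine nitrogen in a ring. Among the compounds with values here, no measured pair shows this same change, so the size of the step cannot be read off from the data and can only be expected. Both measured compounds keep a six-membered aromatic ring that compound 3 lacks, and both give low numbers in this assay, compound 1 with 7.7 nM and compound 2 with 2.2 nM. On that basis the expected step of a 14-fold higher number from compound 2 to compound 3 (1.13 log units; beyond the scatter) is toward a higher number, beyond the scatter, though the evidence is thin. Compound 3 is therefore expected to give about 30 nM in this assay, with a likely range from 8 nM to 120 nM.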

Compound 3, inhibition constant: 4.3 nM
For compound 3 the middle estimate is 7.0-fold (0.84 log units) above the measured one, and the stated range ends above it.
By their numbers in this assay, from the lowest: compounds 2, 3 and 1 (each within the scatter of the next, the first and the last beyond it).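

On the amine nitrogen in the ring, the six-membered aromatic ring proves dispensable in this assay: propyl in place of 4-methoxyphenyl on the saturated chain carbon gives a change that stays within the scatter (that is, a 2.0-fold higher number from compound 2 to compound 3 (0.29 log units; within the scatter)), and so does hydrogen in place of phenyl on the saturated chain carbon four bonds along the chain from that nitrogen (that is, a 1.8-fold lower number from compound 1 to compound 3 (0.25 log units; within the scatter)). The earlier compounds shown here all carried such a ring, so they could not show whether a low number depended on it, whereas compound 3 with 4.3 nM shows that a chain with no ring at all is enough to keep the number in the same range as its two neighbours in these pairs. No measurement shown here accounts for this tolerance.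

Still open, from the compounds shown here alone, is whether the tolerance extends to other groups on this nitrogen, such as a plain methyl, a longer alkyl chain or a cyclohexylmethyl group. Going by these compounds, it is equally open whether a chain ending in a hydroxyl group, an amine or a carboxylic acid would stay within the scatter of compound 3 or move clearly away from it.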